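A few compounds are considered here, and "the series" means these few. Any claim that something is new, unique, unknown or untested is made for them only; others in the source may bear on it.

Working notes on the series. The shared core, as in compound 3 `COc1cc(C(=O)/C=C/c2cc(-c3cc(OC)c(OC)c(OC)c3)n[nH]2)cc(OC)c1OC`, carries a trimethoxyphenyl ring at each end. Compound 1 `COc1ccc(C(=O)/C=C/c2cc(-c3cc(OC)c(OC)c(OC)c3)n[nH]2)cc1OC` and compound 2 `COc1ccc(C(=O)/C=C/c2cc(-c3cc(OC)c(OC)c(OC)c3)n[nH]2)cc1` vary the ring on the ketone side. In a functional assay on MOLT-4 cells (Homo sapiens) for cytotoxicity, read by sulforhodamine B assay, with a stated time of 48 h, tested at 100 uM (on this read-out higher numbers stand for a weaker effect at the one concentration tested and lower numbers for a stronger effect), compound 1 gives -23%, compound 2 gives -4% and compound 3 gives -15%. On these three numbers compound 3 stands second highest; its gap to compound 1 is within the scatter, while compound 2 sits beyond the scatter above it.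

Compound 4 `COc1ccc(-c2cc(/C=C/C(=O)c3cc(OC)c(OC)c(OC)c3)[nH]n2)cc1OC` differs from compound 3 by hydrogen in place of methoxy on an aromatic carbon. Here the change falls on the ring attached to the pyrazole, not on the ketone-side ring. Among the measured compounds shown here, the one measured step of the same kind, a number 19 percentage points higher from compound 1 to compound 2 (beyond the scatter), lies beyond the scatter and points toward a weaker effect. The reverse change, a number 8 percentage points higher from compound 1 to compound 3 (within the scatter), stayed within the scatter. The step now in question is on a different ring, so its size is open.

For the measured compounds named here, because a number 19 percentage points higher from compound 1 to compound 2 (beyond the scatter) is the only guide, compound 4 is expected to show a moderate rise, a number 12 percentage points higher from compound 3 to compound 4 (beyond the scatter). Compound 4 is estimated at -3%, with a range of -28% to 20%.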

Compound 4, a percentage reported as activity, at one concentration (the size of the read-out at that concentration, not a potency): -15%
The estimate for compound 4 lay 12 percentage points above the measured number; the range from low to high includes it.
By their numbers in this assay, from the lowest: compounds 1, 3 and 4 (each within the scatter of the next); then compound 2.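

In this assay, hydrogen in place of methoxy on an aromatic carbon, ortho to a methoxy group and meta to a large group, gives no change at the digits printed from compound 3 to compound 4 (within the scatter). Among the compounds shown here, at the one concentration tested, the read-out of this core therefore does not depend on this methoxy group, which the earlier compounds could not show, since their only step of this kind lay on the ketone-side ring. The same replacement does not carry a single step size from one core to the other, so the step from the earlier pair cannot be transferred to this position: the same change on two cores in this assay, a number 19 percentage points higher (beyond the scatter) from compound 1 to compound 2 and no change at the digits printed (within the scatter) from compound 3 to compound 4, 19 percentage points apart, beyond the scatter of two such steps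

The compounds shown leave open whether a larger or charged group on this same aromatic carbon, such as an amine, a carboxylic acid or a longer chain like butoxy, would leave the read-out as compound 4 leaves it at -15%. As far as these compounds go, a read-out at one concentration is also not a potency, so whether compound 3 and compound 4 would separate at lower concentrations remains open.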